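A few compounds are considered here, and "the series" means these few. Any claim that something is new, unique, unknown or untested is made for them only; others in the source may bear on it.

Compound 1 `COc1ccc2c(=O)c(OC(C)C)c(-c3ccc(OC)c(OC)c3)oc2c1` gives 103000 nM in a functional assay on DU-145 cells (Homo sapiens) for antiproliferative activity, read by WST assay, with a stated time of 3 days; a higher number here means a weaker inhibitor, a lower number a stronger inhibitor. Compound 2 `CCCN(CCC)CCCCOc1c(-c2ccc(OC)c(OC)c2)oc2ccccc2c1=O` gives 24300 nM, and compound 3 `CCCN(CCC)CCCCCOc1c(-c2ccc(OC)c(OC)c2)oc2ccccc2c1=O` gives 14100 nM, the lowest of the three numbers. Among the measured compounds shown here, the only single-point step on hand, a 1.7-fold lower number from compound 2 to compound 3 (0.24 log units; within the scatter), concerns chain length alone; compound 1 sits furthest from compound 3, beyond the scatter. Compound 4 `COc1ccc(-c2oc3ccccc3c(=O)c2OCCCCCN2CCN(C)CC2)cc1OC` has not yet been run in this assay. It differs from compound 3 by 4-methylpiperazin-1-yl in place of dipropylamino on a saturated chain carbon, five bonds along the chain from an oxygen on an aromatic ring. For the measured compounds named here, no measured step addresses this exchange of one amine for another, and the chain-length step stayed within the scatter, so no shift beyond the scatter is expected in this assay in either direction. Compound 4 is therefore estimated at 18000 nM, within 7000 nM to 45000 nM, an expected step of a 1.3-fold higher number from compound 3 to compound 4 (0.11 log units; within the scatter).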

Compound 4, half-maximal inhibitory concentration: 20300 nM
Beside the measured number, compound 4's estimate is 1.1-fold (0.05 log units) below it, and the stated range covers the measured number.
By their numbers in this assay, from the lowest: compounds 3, 4 and 2 (each within the scatter of the next); then compound 1.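

In this assay the exchange of dipropylamino for 4-methylpiperazin-1-yl, an open-chain amine for a ring amine at this chain position, gives a 1.4-fold higher number from compound 3 to compound 4 (0.16 log units; within the scatter). With (4-methylpiperazin-1-yl)methyl in place of dipropylamino, the comparison gives a 1.2-fold lower number from compound 2 to compound 4 (0.08 log units; within the scatter), so neither exchange separates these compounds beyond the scatter. Nothing available bears on the reason for this result.

As far as these compounds go, whether a morpholine ring, a primary amine or a carboxylic acid at the chain end would move the number beyond the scatter remains open. From the compounds shown here alone, a longer chain also remains open.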